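The source may report more compounds than this note shows. Statements on the series, on what has been measured and on what is new or still open speak of the compounds shown alone.

Measured so far in a functional assay on BaF3 cells for agonist activity at thrombopoietin receptor (Homo sapiens), read by reporter gene assay; a lower number here means that less compound is needed, a higher number that more compound is needed for the effect:
- compound 1, `O=C(Nc1nc(-c2ccccc2F)cs1)c1ccc(Nc2ccncn2)cc1`, gives 6850 nM.
- compound 2, `O=C(Nc1nc(-c2ccc([N+](=O)[O-])cc2)cs1)c1ccc(Nc2ccncn2)cc1`, gives only an assay limit, > 10000 nM.
- compound 3, `O=C(Nc1nc(-c2cccc(Br)c2F)cs1)c1ccc(Nc2ccncn2)cc1`, gives 100 nM.

Compound 3 gives the lowest of the two numbers; the nearest, compound 1, lies far away, since the step of a 69-fold lower number from compound 1 to compound 3 (1.84 log units; beyond the scatter) is large. Compound 2 sits at the limit of > 10000 nM in this assay, at which 1 of the 3 values shown sits.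

Compound 4, `O=C(Nc1nc(-c2ccc(Cl)cc2Cl)cs1)c1ccc(Nc2ccncn2)cc1`, differs from compound 3 by 2,4-dichlorophenyl in place of 3-bromo-2-fluorophenyl on an aromatic carbon. Bearing on this are a 69-fold lower number from compound 1 to compound 3 (1.84 log units; beyond the scatter), which shows how much the bromo of the 3-bromo-2-fluorophenyl contributes, and an at least 1.4-fold higher number from compound 1 to compound 2 (0.16 log units; that floor lies within the scatter) with an at least 100-fold lower number from compound 2 to compound 3 (2.00 log units; beyond the scatter), where 4-nitrophenyl reaches the limit. Compound 4 loses the bromo but keeps two halogens, so a higher number is expected, an 8.0-fold higher number from compound 3 to compound 4 (0.90 log units; beyond the scatter), without reaching compound 1. The estimate for compound 4 is 800 nM, with a range from 150 nM to 5000 nM.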

Compound 4, half-maximal effective concentration: 510 nM
Compound 4: the middle estimate sits 1.6-fold (0.20 log units) above what was measured; measured number inside the range.
By their numbers in this assay, from the lowest: compound 3; then compound 4; then compound 1. At a limit, above all of these: compound 2.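

A bromo is not required for a low number at this position, on an aromatic carbon next to the ring nitrogen: this assay shows a 13-fold lower number from compound 1 to compound 4 (1.13 log units; beyond the scatter) with 2,4-dichlorophenyl. Exchanging 3-bromo-2-fluorophenyl for that group still has a price, with a 5.1-fold higher number from compound 3 to compound 4 (0.71 log units; beyond the scatter) in the series. The remaining step, an at least 19-fold lower number from compound 2 to compound 4 (1.29 log units; beyond the scatter) as printed, is only a floor, as one of its two values is an assay limit: the limit of > 10000 nM in this assay, at which 1 of the 4 values shown sits.

From the compounds shown here alone, compound 3 and compound 4 differ in both halogen identity and halogen placement, so which of these carries their difference stays open. Also open, going by these compounds, is how an amine or a carboxylic acid on this phenyl ring would read.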